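The compounds below may be only part of what the source reports. "The series", "measured", "known", "first", "only" and "open" are said of these compounds alone.

Compound 2 `COc1ccccc1NC(=O)CN1CCN(S(=O)(=O)N2CCC(C)CC2)CC1` stands at the edge of an assay on HEK293 cells for inhibition of potassium channel subfamily T member 1 (Homo sapiens), read by thallium flux; a lower number here means a stronger inhibitor, a higher number a weaker inhibitor: it gives > 10000 nM, which is a limit of the assay and not a number (the limit of > 10000 nM in this assay, at which 1 of the 3 values shown sits). Within the data shown here, compound 1 `COc1ccc(C(F)(F)F)cc1NC(=O)CN1CCN(S(=O)(=O)N2CCC(C)CC2)CC1` gives 2400 nM in this assay, and the step of an at least 4.1-fold higher number from compound 1 to compound 2 (0.61 log units; beyond the scatter) is the one measured step that bears here, as it also exchanges hydrogen and trifluoromethyl on an aromatic carbon. Compound 3 `COc1ccc(Cl)cc1NC(=O)CN1CCN(S(=O)(=O)N2CCN(S(=O)(=O)c3ccc(Cl)cc3)CC2)CC1` gives 2300 nM in this assay. Compound 4 `COc1ccc(F)cc1NC(=O)CN1CCN(S(=O)(=O)N2CCC(C)CC2)CC1` differs from compound 2 by fluoro in place of hydrogen on an aromatic carbon. Fluoro is a smaller substituent than trifluoromethyl, so a gain is expected but a modest one, estimated at an at least 1.6-fold lower number from compound 2 to compound 4 (0.22 log units; that floor lies within the scatter). Compound 4 is therefore estimated at 6000 nM in this assay, within a range from 2500 nM to 15000 nM, with a real chance of another limit.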

Compound 4, half-maximal inhibitory concentration: 4900 nM
For compound 4 the middle estimate is 1.2-fold (0.09 log units) above the measured one; measured number inside the range.
By their numbers in this assay, from the lowest: compounds 3 and 1 (each within the scatter of the next); then compound 4. At a limit, above all of these: compound 2.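

Fluoro in place of hydrogen, para to a methoxy group, gives an at least 2.0-fold lower number from compound 2 to compound 4 (0.30 log units; that floor lies within the scatter); compound 2 is at a limit, so the true size of this gain remains unfixed. Trifluoromethyl at the same position outperforms fluoro, with a 2.0-fold higher number from compound 1 to compound 4 (0.31 log units; beyond the scatter), so the outcome here depends on which group replaces hydrogen and not only on the replacement itself.

As far as these compounds go, how a nitrile or an amine at this position would compare remains open. Chloro appears only in compound 3, which also differs elsewhere, so it cannot be ranked against fluoro or trifluoromethyl.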